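This account rests on a few compounds, and the source may have more. Where it says the series, first, only, none or still open, it means among the compounds named here.

Measured so far, in a functional assay on RCC4 cells (Homo sapiens) for inhibition, read by XTT assay, with a stated time of 4 days; on this read-out lower numbers stand for stronger inhibition and higher numbers for weaker inhibition: compound 1 `Cc1cccc(Nc2nc(-c3ccncc3C#CCCO)cs2)c1` gives 1100 nM; 6310 nM (2 entries); compound 2 `CCc1cnccc1-c1csc(Nc2cccc(C)c2)n1` gives 6310 nM; compound 3 `Cc1cccc(Nc2nc(-c3ccncc3OCCCN(C)C)cs2)c1` gives 2700 nM; 2750 nM (2 entries).

Compound 2 stands at the only number shown for it in this assay; two further entries for it carry no single number. The entries of compound 1 spread widely (the several entries of compound 1 in this assay, 1100 nM; 6310 nM (2 entries)), while those of compound 3 sit close together (the several entries of compound 3 in this assay, 2700 nM; 2750 nM (2 entries)).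

Compound 4 `Cc1cccc(Nc2nc(-c3ccncc3CCCO)cs2)c1` differs from compound 2 by hydroxymethyl in place of hydrogen on a saturated chain carbon, two bonds along the chain from an aromatic carbon. Going by the values given here, with no measured step to compare against, the step from compound 2 to compound 4 is expected to be small, at most a modest gain not clearly beyond the scatter a 1.8-fold lower number from compound 2 to compound 4 (0.26 log units; within the scatter). Compound 4 is therefore estimated at 3500 nM in this assay, within 1200 nM to 10000 nM.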

Compound 4, half-maximal inhibitory concentration: 6920 nM
Estimate against measurement, compound 4: 2.0-fold (0.30 log units) below; low and high end bracket the measured number.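

At the saturated chain carbon, two bonds along the chain from an aromatic carbon, hydroxymethyl in place of hydrogen leaves the number in this assay essentially unmoved: a 1.1-fold higher number from compound 2 to compound 4 (0.04 log units; within the scatter). Read as ethyl to 3-hydroxypropyl, this single step shows that the chain can carry the added hydroxymethyl with no change beyond the scatter. Nothing measured here bears on why the step is so small.

As far as these compounds go, whether a carboxylic acid or an amide at the end of this chain would move the number remains open. So does whether any group here could shift it beyond the scatter.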